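Hydroxamate series: ethoxy in place of chloro

The source may hold more compounds than are shown below. What is called first, only, known or untested is meant among the compounds shown, and "the series" means these compounds.

Measured compounds:
compound 1 `O=C(CCC1=CCN(CCCc2ccc(Br)cc2)C1=O)NO` — 5100 nM in a functional assay on HCT-15 cells (Homo sapiens) for inhibition, read by sulforhodamine B assay; on this read-out higher numbers stand for weaker inhibition of growth and lower numbers for stronger inhibition of growth
compound 2 `Cc1cccc(CN2CC=C(CCC(=O)NO)C2=O)c1` — 4720 nM
compound 3 `O=C(CCC1=CCN(CCCc2ccc(Cl)cc2)C1=O)NO` — 5100 nM

In this assay compound 3 stands level with compound 1, the two together giving the highest of the three numbers; compound 2 lies a shade lower but within the scatter, so the three cannot be ordered. Among the measured compounds shown here, the single step between measured compounds, no change at the digits printed from compound 1 to compound 3 (within the scatter), shows that exchanging one halogen for the other left growth inhibition untouched.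

Compound 4 `CCOc1ccc(CCCN2CC=C(CCC(=O)NO)C2=O)cc1` differs from compound 3 by ethoxy in place of chloro on an aromatic carbon. For the measured compounds named here, no measured step exchanges a halogen for an ethoxy group on this ring, so the only guidance is the indifference of the series to the substituent so far: compound 1 and compound 3 do not differ, and compound 2, with another linker and substituent, gives 4720 nM close to both. The step of a 1.0-fold lower number from compound 3 to compound 4 (0.01 log units; within the scatter) is therefore expected to stay within the scatter, with no direction favoured. Compound 4 is estimated at 5000 nM, between 2000 nM and 12000 nM.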

Compound 4, concentration for 50% growth inhibition: 5100 nM
Beside the measured number, compound 4's estimate is 1.0-fold (0.01 log units) below it; the measured number falls inside the stated range.
By their numbers in this assay, from the lowest: compounds 2, 1, 3 and 4 (each within the scatter of the next).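

In this assay, the position para to a large group on the six-membered aromatic ring accepts more than an exchange of one halogen for another: the series shows no change at the digits printed from compound 3 to compound 4 (within the scatter) and no change at the digits printed from compound 1 to compound 4 (within the scatter). Ethoxy brings three heavy atoms and one hydrogen-bond acceptor where chloro and bromo bring a single heavy atom and no acceptor, so this larger difference in the substituent also leaves the read-out within the scatter. No accompanying data bear on why growth inhibition stays level across these substituents.

From the compounds shown here alone, whether a charged group, such as an amine or a carboxylic acid, would be accepted on this carbon remains open. So does whether a longer alkoxy chain in place of ethoxy would keep the number level.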